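A few compounds are considered here, and "the series" means these few. Any claim that something is new, unique, unknown or untested is made for them only; others in the source may bear on it.

Compound 2 `CCCc1c(COc2ccc(C(=O)CCC(=O)O)cc2)ccc(C(C)=O)c1O` gives 6.75 in a functional assay on ileum (Cavia porcellus) with cysteinyl leukotriene receptor (Homo sapiens) as the target (on this read-out higher numbers stand for higher potency (the scale is a negative logarithm) and lower numbers for lower potency), the lower of the two values recorded; compound 1 `CCCc1c(COc2ccc(C(=O)Cc3nnn[nH]3)cc2)ccc(C(C)=O)c1O` gives 7.71 in this assay. Compound 3 `CCCc1c(COc2ccc(C(=O)CCc3nnn[nH]3)cc2)ccc(C(C)=O)c1O` is not yet measured and differs from compound 2 by 1H-tetrazol-5-yl in place of carboxy on a saturated chain carbon, two bonds along the chain from a carbonyl carbon. Among the measured compounds shown here, the one step that bears on this exchange is a number 0.96 log units lower from compound 1 to compound 2 (beyond the scatter), the reverse swap made one bond nearer the carbonyl carbon. Compound 3 is therefore expected to gain, with a step of about a number 0.75 log units higher from compound 2 to compound 3 (beyond the scatter) in this assay. Compound 3 is estimated at 7.5, expected to lie between 6.9 and 8.1.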

Compound 3, negative logarithm of the antagonist equilibrium constant: 7.09
Compound 3: the middle estimate sits 0.41 log units above what was measured; measured number inside the range.
By their numbers in this assay, from the lowest: compound 2; then compound 3; then compound 1.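

In this assay, 1H-tetrazol-5-yl in place of carboxy on a saturated chain carbon, two bonds along the chain from a carbonyl carbon, gives a number 0.34 log units higher from compound 2 to compound 3 (beyond the scatter) on a chain of unchanged length. Placing the same ring one carbon further out, as (1H-tetrazol-5-yl)methyl in place of 1H-tetrazol-5-yl, gives a number 0.62 log units lower from compound 1 to compound 3 (beyond the scatter) and leaves compound 1 the most potent of the three. No measurement here accounts for either step.

Still open, as far as these compounds go, is how a longer chain carrying 1H-tetrazol-5-yl would fare. The effect of a sulfonic acid at this position is also unknown.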